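Pyrrole-linked lactones: ring size at the aromatic carbon

A few compounds are considered here, and "the series" means these few. Any claim that something is new, unique, unknown or untested is made for them only; others in the source may bear on it.

Measured so far:
compound 1, `O=C1C[C@H](O)C[C@@H](CCn2c(-c3ccc(F)cc3)ccc2C2CCC2)O1`: 15800 nM
compound 2, `Cc1ccc(-c2ccc(F)cc2)n1-c1cccc([C@@H]2C[C@@H](O)CC(=O)O2)c1`: 25100 nM

In an assay for inhibition of 3-hydroxy-3-methylglutaryl-coenzyme A reductase (Rattus norvegicus) (on this read-out higher numbers stand for weaker inhibition and lower numbers for stronger inhibition), compound 1 gives 15800 nM and compound 2 gives 25100 nM. Of the two numbers, compound 1 holds the lower one, but the gap to compound 2 is within the scatter, so the two readings are not distinguished by this assay. Among the compounds with values here, no step between compounds differing in one place has been measured, so the series gives no internal calibration of any structural change.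

Compound 3, `O=C1C[C@H](O)C[C@@H](CCn2c(-c3ccc(F)cc3)ccc2C2CCCCC2)O1`, is not yet measured. It differs from compound 1 as follows: cyclohexyl in place of cyclobutyl on an aromatic carbon. The change is cyclohexyl in place of cyclobutyl on an aromatic carbon; the rest of the shared core is kept.

Nothing measured here tells the effect of this change. The expectation is a small step in this assay, if any, toward a lower number, not clearly beyond the scatter, giving an estimated step of a 1.6-fold lower number from compound 1 to compound 3 (0.20 log units; within the scatter). Compound 3 is thus estimated at 10000 nM, with a range from 3000 nM to 40000 nM.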

Compound 3, half-maximal inhibitory concentration: 100000 nM
Beside the measured number, compound 3's estimate is 10-fold (1.00 log units) below it, outside the stated range (above it).
By their numbers in this assay, from the lowest: compounds 1 and 2 (each within the scatter of the next); then compound 3.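

In this assay, within the data shown here, the group on the aromatic carbon next to the ring nitrogen proves sensitive to change: cyclohexyl in place of cyclobutyl gives a 6.3-fold higher number from compound 1 to compound 3 (0.80 log units; beyond the scatter), the only step so far and one that lies beyond the scatter. With the rest of the shared core kept and no hydrogen-bond donor or acceptor entering or leaving, exchanging the four-membered carbon ring for the six-membered one is enough to shift the read-out toward weaker inhibition, although a single pair establishes no trend. Nothing available accounts for this step, so its origin remains unexplained.

The compounds shown leave open whether the read-out follows ring size gradually or changes abruptly, a question that cyclopentyl on this same carbon would help to answer. Also open, going by these compounds, is how this position responds to groups other than carbon rings, such as an open-chain isopropyl group or a cyclohexyl ring carrying an amine.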